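Replacing Iodo with Methoxy on the Shared Core

The compounds below may be only part of what the source reports. "The series", "measured", "known", "first", "only" and "open" are said of these compounds alone.

Measured in a functional assay on HCT-116 cells (Homo sapiens) for inhibition; a lower number here means a stronger inhibitor of growth, a higher number a weaker inhibitor of growth:
Compound 1 `NC(=O)c1cc(Cl)ccc1NC(=O)COc1ccccc1`: 2720 nM
Compound 2 `NC(=O)c1cc(I)ccc1NC(=O)COc1ccccc1`: 517 nM

Going by the values given here, compound 2 holds the lower of the two numbers in this assay, and its only neighbour is compound 1 at 2720 nM. Compound 3 `COc1ccc(NC(=O)COc2ccccc2)c(C(N)=O)c1`, not yet measured, keeps the shared core and changes one group: methoxy in place of iodo on an aromatic carbon. That is methoxy in place of iodo on an aromatic carbon.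

Among the compounds with values here, one measured step bears on this change, iodo in place of chloro on an aromatic carbon, a 5.3-fold lower number from compound 1 to compound 2 (0.72 log units; beyond the scatter). Neither measured compound carries methoxy, so the data offer no direct reading for that group. Compound 2 gained its lower number with iodo in the step of a 5.3-fold lower number from compound 1 to compound 2 (0.72 log units; beyond the scatter), so losing iodo is expected to give a modest step upward in this assay. The expected change is a 4.8-fold higher number from compound 2 to compound 3 (0.68 log units; beyond the scatter). For compound 3 the estimate is 2500 nM, with an expected range of 800 nM to 8000 nM.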

Compound 3, concentration for 50% growth inhibition: 518 nM
Compound 3: the middle estimate sits 4.8-fold (0.68 log units) above what was measured, and the stated range ends above it.
By their numbers in this assay, from the lowest: compounds 2 and 3 (each within the scatter of the next); then compound 1.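

In this assay, methoxy in place of iodo on this aromatic carbon, para to a large group, gives a 1.0-fold higher number from compound 2 to compound 3 (0.00 log units; within the scatter), so the assay does not separate these two groups at this position. Compared with chloro, methoxy gives a 5.3-fold lower number from compound 1 to compound 3 (0.72 log units; beyond the scatter), a step of the same printed size as the one seen with iodo, which shows that the lower number at this position is not unique to iodo. No measurement on hand offers a reason for this result.

The compounds shown leave open whether an amine, a hydroxyl or a longer chain such as ethoxy on this carbon would match iodo and methoxy or chloro. They also leave open whether a methyl group, which has no oxygen, would give a number like that of methoxy.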